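Working notes: chloro replaced by dimethylcarbamoyl on the shared core

This account rests on a few compounds, and the source may have more. Where it says the series, first, only, none or still open, it means among the compounds named here.

Measured compounds:
- compound 1 `O=C(CCCCCCc1ccccc1)c1ncc(C(=O)C(F)(F)F)o1` gives 1820 nM in an assay on HEK-293T cells for inhibition of diacylglycerol lipase-alpha (Homo sapiens), read by colorimetric assay; a lower number here means a stronger inhibitor, a higher number a weaker inhibitor
- compound 2 `CC(=O)c1cnc(C(=O)CCCCCCc2ccccc2)o1` gives > 10000 nM in this assay; this is a limit of the assay
- compound 3 `O=C(CCCCCCc1ccccc1)c1ncc(Cl)o1` gives > 10000 nM in this assay; this is a limit of the assay

Compound 3 stands at the limit of > 10000 nM in this assay, at which 2 of the 3 values shown sit, so its position among the three is only bounded from one side. The step of an at least 5.4-fold higher number from compound 1 to compound 3 (0.73 log units; beyond the scatter) shows that trading the (trifluoromethyl)carbonyl for chloro loses potency. The step of an at least 5.4-fold higher number from compound 1 to compound 2 (0.73 log units; beyond the scatter), methyl in place of trifluoromethyl on the carbonyl carbon, is of the same size. The pair compound 2 and compound 3 gives a step that the two limits leave unreadable from compound 2 to compound 3, since both sit at the limit.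

Compound 4 `CN(C)C(=O)c1cnc(C(=O)CCCCCCc2ccccc2)o1` differs from compound 3 by dimethylcarbamoyl in place of chloro on an aromatic carbon. The change puts a carbonyl-bearing group back in the position where compound 1 carries its (trifluoromethyl)carbonyl, but a dimethylcarbamoyl is closer in kind to the acetyl of compound 2, which itself sits at the limit. Among the measured compounds shown here, no measured step reports a carbamoyl here. The expectation for compound 4 is therefore 15000 nM, with a range from 4000 nM to 60000 nM, most likely again reported as a limit. That expected step is a step that the limit leaves unreadable from compound 3 to compound 4.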

Compound 4, half-maximal inhibitory concentration: > 10000 nM
Compound 4 gave a limit, no number (the forecaster's own chance of this, stated with the estimate: 70%); the middle value lies beyond the limit too.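

With dimethylamino in place of trifluoromethyl on the carbonyl carbon, this assay shows an at least 5.4-fold higher number from compound 1 to compound 4 (0.73 log units; beyond the scatter). The steps from compound 3 to compound 4 and from compound 2 to compound 4 cannot be read, as both ends of each are limits. Among the compounds shown, only the (trifluoromethyl)carbonyl on this aromatic carbon gives a number, and a carbonyl at this place is not enough by itself, for the acetyl of compound 2 and the dimethylcarbamoyl of compound 4 end at a limit, as the chloro of compound 3 does: the limit of > 10000 nM in this assay, at which 3 of the 4 values shown sit.

Still open, from the compounds shown here alone, is whether difluoromethyl or pentafluoroethyl on the carbonyl carbon, or a nitrile or a carboxylic acid on the aromatic carbon, would give a number rather than a limit. Also open, going by these compounds, is whether a longer or shorter chain in place of the phenyl-bearing chain would move compound 1 from its 1820 nM in this assay.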